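This account rests on a few compounds, and the source may have more. Where it says the series, first, only, none or still open, it means among the compounds named here.

Measured compounds:
compound 1, `O=C(NCCCCC(c1ccc(F)cc1)c1ccc(F)cc1)Nc1ccc(Cl)cc1`, in an ADME assay on isolated protein for inhibition of sodium-dependent dopamine transporter (Homo sapiens) (on this read-out higher numbers stand for weaker inhibition and lower numbers for stronger inhibition), compound 1 gives 15 nM
compound 2, `O=C(NCCCCC(c1ccc(F)cc1)c1ccc(F)cc1)Nc1ccc(Cl)c(C(F)(F)F)c1`, in this assay compound 2 gives 6.5 nM
compound 3, `Cc1ccc(C(CCCCNC(=O)Nc2ccc(Cl)c(C(F)(F)F)c2)c2ccc(C)cc2)cc1`, in this assay compound 3 gives "not determined" (no result reported)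

The change from compound 2 to compound 1 is hydrogen in place of trifluoromethyl on an aromatic carbon, and it made a 2.3-fold higher number from compound 2 to compound 1 (0.36 log units; beyond the scatter). Compound 4, `Cc1ccc(C(CCCCNC(=O)Nc2ccc(Cl)cc2)c2ccc(C)cc2)cc1`, has not yet been measured. It differs from compound 3 by hydrogen in place of trifluoromethyl on an aromatic carbon, the same change at the same place. How the core of compound 3 differs from that of compound 2 is not broken down here, and compound 3 itself carries no number. The expectation for compound 4 therefore rests on compound 1, whose value 15 nM shows the level reached with the same urea end; the step seen between compound 2 and compound 1 is modest, but the other end of compound 4 is not covered by any measured pair, so the range is kept wide. Compound 4 is expected to give about 30 nM in this assay. Its estimated range runs from 8 nM to 120 nM.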

Compound 4, inhibition constant: 535 nM
Compound 4: middle estimate off by 18-fold (1.25 log units), on the low side, outside the stated range (above it).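

With no single number for compound 3 in this assay, the step to compound 4 cannot be read. The compounds shown leave open how much trifluoromethyl counts on the core of compound 4. Nothing shown accounts for this result.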